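The compounds below may be only part of what the source reports. "The series", "measured", "known", "first", "only" and "open" are said of these compounds alone.

Measured so far in an ADME assay on HepG2 2.2.15 cells (Homo sapiens) for cytotoxicity, read by MTT assay, with stated times of 48 h and 9 days; on this read-out higher numbers stand for lower toxicity in this test and lower numbers for higher toxicity in this test:
- compound 1 `COc1ccc2c(=O)c(/C=C/C(=O)Nc3ccccc3Cl)coc2c1`: 1010000 nM
- compound 2 `COc1cccc(NC(=O)/C=C/c2coc3cc(OC)ccc3c2=O)c1`: 1130000 nM
- compound 3 `COc1ccc2c(=O)c(/C=C/C(=O)NCc3cccc(F)c3)coc2c1`: 475000 nM

In this assay, compound 3 gives 475000 nM, the lowest number of the three. Compound 4 `COc1ccc2c(=O)c(/C=C/C(=O)NCc3ccc(F)cc3)coc2c1` keeps the shared core and the amide. The change is 4-fluorophenyl in place of 3-fluorophenyl on a saturated chain carbon bound to an amide-type nitrogen, with 4-fluorophenyl in place of 3-fluorophenyl on a saturated chain carbon bound to an amide-type nitrogen.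

Among the compounds with values here, no measured step isolates this exchange, so the evidence is only indirect. Replacing the whole group on the amide-type nitrogen gave modest steps: a 2.1-fold lower number from compound 1 to compound 3 (0.33 log units; beyond the scatter) and a 2.4-fold lower number from compound 2 to compound 3 (0.38 log units; beyond the scatter). The exchange between the two aryl groups stayed within the scatter: a 1.1-fold higher number from compound 1 to compound 2 (0.05 log units; within the scatter). A smaller change than those two modest steps therefore points to no shift beyond the scatter, and no direction can be favoured.

The expected outcome is a 1.1-fold higher number from compound 3 to compound 4 (0.02 log units; within the scatter). Compound 4 is estimated at 500000 nM. The expected range for compound 4 is 250000 nM to 1000000 nM.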

Compound 4, half-maximal cytotoxic concentration: 133000 nM
Estimate against measurement, compound 4: 3.8-fold (0.58 log units) above; the whole stated range lies above it.
By their numbers in this assay, from the lowest: compound 4; then compound 3; then compounds 1 and 2 (each within the scatter of the next).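

In this assay, the change from 3-fluorobenzyl to 4-fluorobenzyl keeps the same atoms and still gives a 3.6-fold lower number from compound 3 to compound 4 (0.55 log units; beyond the scatter). The place of the fluorine on the phenyl ring alone is therefore enough to move the number beyond the scatter, which the earlier exchanges of the whole group on the amide-type nitrogen could not show; with the whole group replaced, the steps reach an 8.5-fold lower number from compound 2 to compound 4 (0.93 log units; beyond the scatter) and a 7.6-fold lower number from compound 1 to compound 4 (0.88 log units; beyond the scatter). No measurement at hand accounts for the difference between the two fluorobenzyl compounds.

Going by these compounds, it remains open whether chlorine in place of the fluorine in the 4-fluorobenzyl group would give a similar number. Also open, on these data alone, is how a longer chain carrying the 4-fluorophenyl on the amide-type nitrogen would read.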